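Hexyloxy for isobutylsulfanyl: notes toward compound 4

A few compounds are considered here, and "the series" means these few. Any claim that something is new, unique, unknown or untested is made for them only; others in the source may bear on it.

Measured so far in an ADME assay on MOLT-3 cells (Homo sapiens) for cytotoxicity, with a stated time of 7 days; on this read-out higher numbers stand for lower toxicity in this test and lower numbers for higher toxicity in this test:
compound 1 `CC(C)CSc1nc(N)nc2c1ncn2/C=C1/CC1(CO)CO` — compound 1 gives "not determined" (no result reported).
compound 2 `Nc1nc(NC2CCCC2)c2ncn(/C=C3/CC3(CO)CO)c2n1` — compound 2 gives > 20000 nM, a limit of this assay.
compound 3 `CSc1nc(N)nc2c1ncn2/C=C1/CC1(CO)CO` — compound 3 gives > 20000 nM, a limit of this assay.

Compound 1 therefore has no number of its own in this assay; the two other readings are limits. Among the compounds with values here, the only step between measured compounds, a step that the two limits leave unreadable from compound 2 to compound 3, cannot be sized because both of its ends rest at the limit (the limit of > 20000 nM in this assay, at which 2 of the 3 values shown sit). Compound 4 `CCCCCCOc1nc(N)nc2c1ncn2/C=C1/CC1(CO)CO` differs from compound 1 by hexyloxy in place of isobutylsulfanyl on an aromatic carbon. Within the data shown here, no measured step bears on this change, so nothing about its direction or size can be read from the series. Compound 4 is expected to sit at or beyond the same limit, estimated at 30000 nM (range 15000 nM to 80000 nM).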

Compound 4, half-maximal cytotoxic concentration: > 20000 nM
Compound 4 gave a limit, no number (the forecaster's own chance of this, stated with the estimate: 85%); the middle value does not contradict the limit.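

No step among compound 2, compound 3 and compound 4 can be read, because all three rest at one limit: the limit of > 20000 nM in this assay, at which 3 of the 4 values shown sit.

The compounds shown leave open what hexyloxy in place of isobutylsulfanyl changes, and where any of this series would give a number.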